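The source may report more compounds than this note shows. Statements on the series, on what has been measured and on what is new or still open speak of the compounds shown alone.

In a functional assay on NUGC-3 cells (Homo sapiens) for antiproliferative activity, read by XTT assay (a lower number here means a stronger inhibitor, a higher number a weaker inhibitor), compound 1 (`O=c1c(Cc2coc3cccc(OCC4CCCCC4)c3c2=O)coc2cc(Cl)ccc12`) gives > 10000 nM, which is a limit of the assay and not a number. Compound 2 (`CC(C)COc1cccc2occ(Cc3coc4ccccc4c3=O)c(=O)c12`) gives > 10000 nM, likewise a limit. Compound 2 therefore has no number of its own and stands at the limit of > 10000 nM in this assay, at which 2 of the 2 values shown sit. Compound 3 (`COc1cccc2occ(Cc3coc4ccccc4c3=O)c(=O)c12`) has hydrogen in place of isopropyl on a saturated chain carbon bound to an oxygen on an aromatic ring, so that isobutoxy becomes methoxy: hydrogen in place of isopropyl on a saturated chain carbon bound to an oxygen on an aromatic ring. For the measured compounds named here, no measured step is available to size this change. The expected step of a number no higher from compound 2 to compound 3 (the limit leaves the size open) is none beyond the scatter, with no direction favoured. Compound 3 is estimated at 10000 nM, with an expected range of 3000 nM to 30000 nM.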

Compound 3, half-maximal inhibitory concentration: 3190 nM
For compound 3 the middle estimate is 3.1-fold (0.50 log units) above the measured one; low and high end bracket the measured number.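

In this assay, the change from isobutoxy to methoxy gives an at least 3.1-fold lower number from compound 2 to compound 3 (0.49 log units; beyond the scatter). For the compounds shown here, this shows that the read-out responds to the group at this place, which the earlier compounds could not show, and compound 3 is the only one of the three with a number. Compound 2 has only a limit of the assay, so the full size of the step remains unknown: the limit of > 10000 nM in this assay, at which 2 of the 3 values shown sit.

The compounds shown leave open how an ethoxy group, a free hydroxyl or an amine-bearing chain at this place would read. They also do not show whether the same change would act alike on another core.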